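Notes on a sulfonamide benzylamide series

The source may report more compounds than this note shows. Statements on the series, on what has been measured and on what is new or still open speak of the compounds shown alone.

Measured so far:
compound 1 `COc1ccccc1C(=O)NCc1ccc(CNS(=O)(=O)c2cccc(Cl)c2)cc1`: 1000 nM
compound 2 `COc1ccccc1C(=O)NCc1ccc(CNS(=O)(=O)c2ccccc2C)cc1`: 1000 nM
compound 3 `O=C(NCc1ccc(CNS(=O)(=O)c2cccc(Cl)c2)cc1)c1cccnc1`: 100 nM

All three values come from an assay on MDA-MB-231 cells for displacement of a labelled ligand from C-X-C chemokine receptor type 4 (Homo sapiens), read by fluorescence and microscopy, with stated times of 10 min and 30 min; a lower number here means that less compound is needed, a higher number that more compound is needed for the effect. Compound 1 and compound 2 differ in 2-methylphenyl in place of 3-chlorophenyl on a sulfonyl sulfur, and the step of no change at the digits printed from compound 1 to compound 2 (within the scatter). Compound 3 carries a different core; against compound 1 the difference is pyridin-3-yl in place of 2-methoxyphenyl on a carbonyl carbon, and the step of a 10-fold lower number from compound 1 to compound 3 (1.00 log units; beyond the scatter). Compound 3 thus stands lowest of the three.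

Compound 4 `Cc1ccccc1S(=O)(=O)NCc1ccc(CNC(=O)c2cccnc2)cc1` is not yet measured. It differs from compound 3 by 2-methylphenyl in place of 3-chlorophenyl on a sulfonyl sulfur, the same change already seen between compound 1 and compound 2, at the same place. In this assay the expected step is no change at the digits printed from compound 3 to compound 4 (within the scatter), resting on the earlier no change at the digits printed from compound 1 to compound 2 (within the scatter), which stayed within the scatter. Compound 4 is therefore estimated at 100 nM, expected to fall between 50 nM and 200 nM.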

Compound 4, effective concentration (reported as EC, without a stated level of effect): 1000 nM
For compound 4 the middle estimate is 10-fold (1.00 log units) below the measured one; measured number outside the range, above it.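

In this assay the change to 2-methylphenyl on the sulfonyl sulfur does not carry over from one core to the other, with a 10-fold higher number from compound 3 to compound 4 (1.00 log units; beyond the scatter): the same change on two cores in this assay, no change at the digits printed (within the scatter) from compound 1 to compound 2 and a 10-fold higher number (1.00 log units; beyond the scatter) from compound 3 to compound 4, 10-fold (1.00 log units) apart, beyond the scatter of two such steps. The pyridin-3-yl change on the carbonyl carbon also depends on its partner, with no change at the digits printed from compound 2 to compound 4 (within the scatter): the same change on two cores in this assay, a 10-fold lower number (1.00 log units; beyond the scatter) from compound 1 to compound 3 and no change at the digits printed (within the scatter) from compound 2 to compound 4, 10-fold (1.00 log units) apart, beyond the scatter of two such steps. Among these four compounds the two changes are therefore not independent, the lower number appearing only in compound 3, which pairs 3-chlorophenyl with pyridin-3-yl, but this does not show why the pairing matters or whether it extends to other groups.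

Open, from the compounds shown here alone, is how the number of compound 3 would respond to an unsubstituted phenyl or a longer alkyl chain on the sulfonyl sulfur. Also open, going by these compounds, is its response to an amine in place of pyridin-3-yl on the carbonyl carbon.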